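Replacing the fluorophenyl of compound 3 with a chloro-methoxyphenyl

The source may hold more compounds than are shown below. What is called first, only, known or untested is meant among the compounds shown, and "the series" means these compounds.

In a functional assay on A2780 cells (Homo sapiens) for antiproliferative activity (on this read-out lower numbers stand for stronger inhibition and higher numbers for weaker inhibition), compound 1 `C#Cc1cccc(Nc2ncnn3ccc(CN4CCC(N)CC4)c23)c1` gives 2300 nM and compound 2 `NC1CCN(Cc2ccn3ncnc(Nc4ccccc4)c23)CC1` gives 3700 nM. Compound 3 `NC1CCN(Cc2ccn3ncnc(Nc4cccc(F)c4)c23)CC1` reaches only a limit of the assay, > 5000 nM, so its position is known merely as a floor, as the limit of > 5000 nM in this assay, at which 1 of the 3 values shown sits, states. The steps leading to it were an at least 2.1-fold higher number from compound 1 to compound 3 (0.33 log units; beyond the scatter) and an at least 1.3-fold higher number from compound 2 to compound 3 (0.13 log units; that floor lies within the scatter). Compound 4 `COc1ccc(Nc2ncnn3ccc(CN4CCC(N)CC4)c23)cc1Cl` differs from compound 3 in a single place: 3-chloro-4-methoxyphenyl in place of 3-fluorophenyl on a nitrogen on an aromatic ring. Within the data shown here, no measured step involves a chloro or a methoxy group, so the only guidance comes from the three aryl substituents already seen, which span a narrow band from compound 1 to the limit reached by compound 3. Compound 4 is therefore expected to stay in that band; the step of an at least 1.4-fold lower number from compound 3 to compound 4 (0.15 log units; that floor lies within the scatter) is an estimate taken from the floor of compound 3 and could well be none beyond the scatter. The estimate for compound 4 is 3500 nM, expected to fall between 1200 nM and 10000 nM, with a real chance that only a limit is reported again.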

Compound 4, half-maximal inhibitory concentration: > 5000 nM
Compound 4: a limit, no number (the forecaster's own chance of this, stated with the estimate: 35%); middle value at least 1.4-fold (0.15 log units) away from the limit.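

In this assay compound 4 gives > 5000 nM, which is again a limit of the assay and not a number. Placing 3-chloro-4-methoxyphenyl on this nitrogen gives an at least 2.1-fold higher number from compound 1 to compound 4 (0.33 log units; beyond the scatter) and an at least 1.3-fold higher number from compound 2 to compound 4 (0.13 log units; that floor lies within the scatter), while the step between compound 3 and compound 4 cannot be read, as both values are limits. Adding chloro and methoxy groups together therefore brought no readable gain, and only compound 1 and compound 2 give numbers at this position, with compound 3 and compound 4 both ending at the same limit: the limit of > 5000 nM in this assay, at which 2 of the 4 values shown sit.

Going by these compounds, how far compound 3 and compound 4 lie beyond that limit stays unknown, so they cannot be ranked against each other. On these data alone, whether an amine or a carboxylic acid on this aromatic ring would bring a value within the range of the assay also stays open.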